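A few compounds are considered here, and "the series" means these few. Any claim that something is new, unique, unknown or untested is made for them only; others in the source may bear on it.

Compound 1, `Cc1ccccc1/C=C1\CCc2ccccc2C1=O`: 41400 nM
Compound 2, `O=C1/C(=C/c2ccccc2Br)CCc2ccccc21`: 36800 nM
Compound 3, `Cc1ccccc1/C=C1\Cc2ccccc2C1=O`: 154000 nM

All three were measured in a functional assay on Molt4/C8 cells (Homo sapiens) for inhibition; on this read-out higher numbers stand for weaker inhibition and lower numbers for stronger inhibition. Compound 1 and compound 2 share one core, while compound 3 is built on another; the difference between the two cores is not broken down here. Within the first pair the change is bromo in place of methyl on an aromatic carbon and it made a 1.1-fold lower number from compound 1 to compound 2 (0.05 log units; within the scatter). Compound 3 stands apart with the highest of the three numbers, beyond the scatter from both others.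

Compound 4, `O=C1/C(=C/c2ccccc2Br)Cc2ccccc21`, has not yet been measured. It carries the same change as the first pair, (bromo in place of methyl on an aromatic carbon), placed on the core of compound 3. Resting on a 1.1-fold lower number from compound 1 to compound 2 (0.05 log units; within the scatter) in the measured pair, the step from compound 3 to compound 4 is expected to be small, a 1.1-fold lower number from compound 3 to compound 4 (0.04 log units; within the scatter). Compound 4 is therefore estimated at 140000 nM, with a likely range from 70000 nM to 280000 nM.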

Compound 4, half-maximal inhibitory concentration: 95400 nM
Estimate against measurement, compound 4: 1.5-fold (0.17 log units) above; the range from low to high includes it.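

Replacing methyl with bromo gave a 1.6-fold lower number from compound 3 to compound 4 (0.21 log units; within the scatter) in this assay. Set beside the earlier pair, the two steps agree: the same change on two cores in this assay, a 1.1-fold lower number (0.05 log units; within the scatter) from compound 1 to compound 2 and a 1.6-fold lower number (0.21 log units; within the scatter) from compound 3 to compound 4, 1.4-fold (0.16 log units) apart, within the scatter of two such steps. The change therefore carries from one core to the other as a step too small to distinguish from assay noise, but two such pairs do not show that methyl and bromo truly differ, or how the change would behave on any further core.

The compounds shown leave open what other groups on this aromatic carbon would do, such as an amine, a carboxylic acid or a longer chain. They also leave open whether any such group would give a step large enough to compare across the two cores.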